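A few compounds are considered here, and "the series" means these few. Any claim that something is new, unique, unknown or untested is made for them only; others in the source may bear on it.

Within the data shown here, compound 2 `Brc1ccc(-c2cn3ccnc3c(-c3ccc4ncn(C5CCCCC5)c4c3)n2)cc1` stands highest of the two numbers measured so far in a functional assay on 786-0 cells (Homo sapiens) for inhibition, read by sulforhodamine B assay, with a stated time of 48 h, tested at 10 uM (a higher number here means more inhibition at the concentration tested (going by the name of the read-out), a lower number less inhibition), where compound 2 gives 18%. Among the measured compounds shown here, the only other compound measured, compound 1 `c1cn2cc(-c3ccsc3)nc(-c3ccc4ncn(C5CCCCC5)c4c3)c2n1`, gives 6.35% in this assay. For the measured compounds named here, the single step known between them, a number 11.7 percentage points higher from compound 1 to compound 2 (beyond the scatter), came from putting 4-bromophenyl in place of thiophen-3-yl on an aromatic carbon.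

Compound 3 `COc1ccccc1-c1cn2ccnc2c(-c2ccc3ncn(C4CCCCC4)c3c2)n1` is the next compound, and it differs from compound 2 in one place: 2-methoxyphenyl in place of 4-bromophenyl on an aromatic carbon

Going by the values given here, no measured step exchanges 4-bromophenyl for 2-methoxyphenyl, so nothing directly bears on this change. Among the compounds with values here, the one step available, a number 11.7 percentage points higher from compound 1 to compound 2 (beyond the scatter), shows that swapping the group on this aromatic carbon can move the number by a modest amount. Since that is the whole of the evidence, compound 3 is expected to stay near compound 2, with a step of about a number 6 percentage points lower from compound 2 to compound 3 (within the scatter) in this assay, which may well fall within the scatter. The estimate for compound 3 in this assay is therefore 12%, within a range from 0% to 30%.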

Compound 3, a percentage reported as inhibition, at one concentration (the size of the read-out at that concentration, not a potency): 12.3%
Beside the measured number, compound 3's estimate is 0.3 percentage points below it; measured number inside the range.
By their numbers in this assay, from the lowest: compounds 1, 3 and 2 (each within the scatter of the next, the first and the last beyond it).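

In this assay, exchanging 4-bromophenyl for 2-methoxyphenyl on this aromatic carbon gives a number 5.7 percentage points lower from compound 2 to compound 3 (within the scatter), and exchanging thiophen-3-yl for 2-methoxyphenyl gives a number 6 percentage points higher from compound 1 to compound 3 (within the scatter). Compound 3 therefore cannot be told apart from either of the other two compounds, although those two are separated by a number 11.7 percentage points higher from compound 1 to compound 2 (beyond the scatter), so the earlier result does not mean that every exchange of one aromatic group for another at this position moves the number beyond the scatter. Nothing available explains why these three groups give the numbers they do.

The compounds shown leave open whether the methoxy group and the bromine count for anything separately from where they sit on the phenyl ring, a question that 4-methoxyphenyl and 2-bromophenyl at the same carbon would address. They also leave open how a non-aromatic group at this carbon, such as an amine or a longer alkyl chain, or a phenyl ring bearing a carboxylic acid, would read in this assay.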